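A few compounds are considered here, and "the series" means these few. Any claim that something is new, unique, unknown or untested is made for them only; others in the source may bear on it.

Measured so far:
- compound 1 `O=C(Nc1ccccc1)c1cccc2oc(=O)[nH]c12`: 2200 nM
- compound 2 `COc1cccc(NC(=O)c2cccc3oc(=O)[nH]c23)c1`: 3900 nM
- compound 3 `O=C(Nc1ccccc1Cl)c1cccc2oc(=O)[nH]c12`: > 10000 nM

In an assay on isolated protein for binding affinity to metabotropic glutamate receptor 5 (Homo sapiens) (a lower number here means a stronger inhibitor, a higher number a weaker inhibitor), compound 1 gives 2200 nM. Compound 2 gives 3900 nM, and the step of a 1.8-fold higher number from compound 1 to compound 2 (0.25 log units; within the scatter) keeps the two within the usual scatter of each other. For compound 3 the assay reports only a limit, > 10000 nM; compound 3 sits at the limit of > 10000 nM in this assay, at which 1 of the 3 values shown sits. The step of an at least 4.5-fold higher number from compound 1 to compound 3 (0.65 log units; beyond the scatter) is therefore the one change beyond the scatter among the numbers shown, so compound 1 stands with compound 2 at the stronger end of the set.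

Compound 4 `Cc1nc(NC(=O)c2cccc3oc(=O)[nH]c23)cs1` carries the change (2-methyl-1,3-thiazol-4-yl in place of phenyl on an amide-type nitrogen). Neither measured step bears directly on it: both keep the phenyl and alter a substituent on it, one tolerated and one not. Going by the values given here, with no step that replaces the ring itself, compound 4 is expected to stay close to compound 1, with a slight lean toward the weaker side, so that the step from compound 1 to compound 4 is estimated as a 1.4-fold higher number from compound 1 to compound 4 (0.13 log units; within the scatter). The estimate for compound 4 in this assay is 3000 nM, within the range 800 nM to 12000 nM.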

Compound 4, inhibition constant: 250 nM
The estimate for compound 4 lay 12-fold (1.08 log units) above the measured number; the measured number lies below the stated range.
By their numbers in this assay, from the lowest: compound 4; then compounds 1 and 2 (each within the scatter of the next). At a limit, above all of these: compound 3.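

In this assay, 2-methyl-1,3-thiazol-4-yl in place of phenyl on the amide-type nitrogen gives an 8.8-fold lower number from compound 1 to compound 4 (0.94 log units; beyond the scatter), the only change shown that lowers the number beyond the scatter. Compound 2 and compound 3 both keep the phenyl: the methoxy of compound 2 stays within the scatter of compound 1, and the chloro of compound 3 gives a weaker compound. This position therefore accepts more than a substituted phenyl, and exchanging the ring itself, at the same heavy-atom count, gives a stronger inhibitor on the shared core.

What in the new ring accounts for the gain cannot be told from the data at hand. From the compounds shown here alone, it also stays open whether the methyl is needed, as a thiazol-4-yl without it or a pyridine ring in the same place would show.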